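Swapping Amino for Methoxy: Predicting a Second Pair

The source may hold more compounds than are shown below. What is called first, only, known or untested is meant among the compounds shown, and "the series" means these compounds.

Compound 1 `Nc1ccccc1/C=C/c1ccccc1O`: 27 ug/mL
Compound 2 `COc1ccccc1/C=C/c1ccccc1O`: 15 ug/mL
Compound 3 `Nc1ccc(/C=C/c2cccc(O)c2)cc1`: 25 ug/mL

These three compounds were measured in an ADME assay on HEK293 cells (Homo sapiens) for inhibition, read by MTT assay, with a stated time of 2 days; on this read-out lower numbers stand for stronger inhibition and higher numbers for weaker inhibition. Compound 4 `COc1ccc(/C=C/c2cccc(O)c2)cc1` has not yet been measured there. Compound 2 arises from compound 1 by methoxy in place of amino on an aromatic carbon, and that step gave a 1.8-fold lower number from compound 1 to compound 2 (0.26 log units; within the scatter). Compound 3 has the same atoms as compound 1 joined differently; the difference between the two cores is not broken down here, and their values in this assay lie within the scatter of each other. Compound 4 arises from compound 3 by methoxy in place of amino on an aromatic carbon. The surroundings differ: in compound 1 the change sits ortho to a group of 9 heavy atoms, in compound 3 it sits para to a group of 9 heavy atoms, so this is the same kind of change, not the same change. Because the earlier step gave a 1.8-fold lower number from compound 1 to compound 2 (0.26 log units; within the scatter), a similar small step, a 1.7-fold lower number from compound 3 to compound 4 (0.22 log units; within the scatter), is expected here. Compound 4 is therefore estimated at 15 ug/mL in this assay, with a likely range from 8 ug/mL to 30 ug/mL.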

Compound 4, half-maximal inhibitory concentration: 24 ug/mL
Compound 4: middle estimate off by 1.6-fold (0.20 log units), on the low side; measured number inside the range.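

In this assay, methoxy in place of amino on the core of compound 3 gave a 1.0-fold lower number from compound 3 to compound 4 (0.02 log units; within the scatter) and so no change that can be told apart from measurement noise. Set beside the same swap on the core of compound 1, the result does not differ by more than repeated measurements would: the same change on two cores in this assay, a 1.8-fold lower number (0.26 log units; within the scatter) from compound 1 to compound 2 and a 1.0-fold lower number (0.02 log units; within the scatter) from compound 3 to compound 4, 1.7-fold (0.24 log units) apart, within the scatter of two such steps. This fits the idea that the swap behaves alike on these two cores, but neither step stands clear of the scatter, so the pair shows no real effect of the change on either core and cannot prove that the effect carries over, and two cores say nothing about a third.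

Only amino and methoxy are compared at these places, so the compounds shown leave open whether a different group, such as ethoxy, dimethylamino or a carboxylic acid, would give a step large enough to read. They also leave open whether such a step would match on both cores.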